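The source may hold more compounds than are shown below. What is called first, only, known or untested is meant among the compounds shown, and "the series" means these compounds.

Measured compounds, cytotoxicity on HCT-116 cells:

compound 1 `Cc1ccc(CSc2cc(Cl)c(C)cc2S(=O)(=O)/N=C(\N)n2nc(C)cc2-c2ccccc2)cc1`: 28000 nM
compound 2 `Cc1cc(S(=O)(=O)/N=C(\N)n2nccc2-c2ccccc2)c(SCc2cccc(Cl)c2)cc1Cl`: 7000 nM
compound 3 `Cc1cc(S(=O)(=O)/N=C(\N)n2nccc2-c2ccccc2)c(SCc2ccccc2)cc1Cl`: 12000 nM

In a functional assay on HCT-116 cells (Homo sapiens) for cytotoxicity, read by MTT assay, with a stated time of 72 h (on this read-out lower numbers stand for stronger inhibition and higher numbers for weaker inhibition), compound 1 stands highest of the three numbers shown. Its nearest neighbour is compound 3, which gives 12000 nM, a gap beyond the scatter; furthest is compound 2 with 7000 nM. Going by the values given here, the only single-point step within the measured set, a 1.7-fold higher number from compound 2 to compound 3 (0.23 log units; within the scatter), concerns a chloro versus hydrogen on the benzyl ring attached to the sulfur and stays within the scatter.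

Compound 4 `Cc1cccc(CSc2cc(Cl)c(C)cc2S(=O)(=O)/N=C(\N)n2nc(C)cc2-c2ccccc2)c1` differs from compound 1 by 3-methylphenyl in place of 4-methylphenyl on a saturated chain carbon bound to a sulfur. Among the compounds with values here, no measured step reproduces this change; the closest information is the step from compound 2 to compound 3, where altering the substitution of that same benzyl ring left this assay essentially unchanged. On that basis a step of no more than the scatter is expected in this assay, with no preferred direction, so compound 4 is expected to remain in the range of compound 1, giving an estimated step of a 1.1-fold lower number from compound 1 to compound 4 (0.05 log units; within the scatter). The estimate for compound 4 in this assay is 25000 nM, with a range from 10000 nM to 60000 nM.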

Compound 4, half-maximal inhibitory concentration: 34000 nM
Estimate against measurement, compound 4: 1.4-fold (0.13 log units) below, within the range that was stated.
By their numbers in this assay, from the lowest: compounds 2 and 3 (each within the scatter of the next); then compounds 1 and 4 (each within the scatter of the next).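

In this assay, the change to 3-methylphenyl in place of 4-methylphenyl on a saturated chain carbon bound to a sulfur gives a 1.2-fold higher number from compound 1 to compound 4 (0.08 log units; within the scatter), so these two placements of the methyl group are not told apart on this read-out. Together with a 1.7-fold higher number from compound 2 to compound 3 (0.23 log units; within the scatter), which is a chloro-to-hydrogen change on the same benzyl ring of a different core, this gives a second step at this position that stays within the scatter, now for an exchange that keeps the same atoms and only joins them differently. No accompanying measurement bears on why the number stays put at this position.

As far as these compounds go, whether this tolerance holds beyond small groups on the benzyl ring stays open: a carboxylic acid or an amine on that ring, or a longer chain in place of the benzyl group, could behave differently. From the compounds shown here alone, the contribution of the methyl group itself also stays open, as does whether the 4-methylphenyl to 3-methylphenyl change gives a similar step on the core of compound 3.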